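The source may hold more compounds than are shown below. What is called first, only, known or untested is meant among the compounds shown, and "the series" means these compounds.

Compound 1 `C=CC[C@H]1C[C@]2([C@@H](C)Cc3ccc(OC)c(OC)c3)OCOC2=CC1=O`: 110 nM
Compound 2 `C=CC[C@H]1C[C@]2(CCc3ccc(OC)c(OC)c3)OCOC2=CC1=O`: 2000 nM

In a functional assay on M14 cells (Homo sapiens) for antiproliferative activity, with a stated time of 72 h (a higher number here means a weaker inhibitor, a lower number a stronger inhibitor), compound 1 gives 110 nM, the lower of the two numbers, so it is the stronger inhibitor of the pair. Within the data shown here, the only measured step is an 18-fold higher number from compound 1 to compound 2 (1.26 log units; beyond the scatter), which puts hydrogen in place of methyl on a saturated chain carbon. Compound 3 `C=CC[C@H]1C[C@]2([C@@H](C)Cc3ccc(OC)c(C#N)c3)OCOC2=CC1=O` is changed elsewhere: cyano in place of methoxy on an aromatic carbon. The new group sits ortho to a methoxy group. The measured step bears on this only indirectly, showing that one small change moved the number far in this pair. Among the measured compounds shown here, no measured compound carries cyano, so the direction is uncertain, and a moderate loss is a cautious guess. The expected change is a 2.7-fold higher number from compound 1 to compound 3 (0.44 log units; beyond the scatter). For compound 3 the estimated value is 300 nM, with an expected range of 60 nM to 1500 nM.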

Compound 3, half-maximal inhibitory concentration: 180 nM
Estimate against measurement, compound 3: 1.7-fold (0.22 log units) above, within the range that was stated.
By their numbers in this assay, from the lowest: compounds 1 and 3 (each within the scatter of the next); then compound 2.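

In this assay, cyano in place of methoxy on this aromatic carbon gives a 1.6-fold higher number from compound 1 to compound 3 (0.21 log units; within the scatter) and so the two compounds cannot be told apart in this assay. This aromatic carbon, ortho to a methoxy group, therefore tolerates the swap in this pair, whereas the change on the saturated chain gave a large step of an 18-fold higher number from compound 1 to compound 2 (1.26 log units; beyond the scatter) in the same assay. Nothing available explains why methoxy and cyano give such similar numbers here.

Going by these compounds, whether an amine, a carboxylic acid or a longer chain such as ethoxy on this carbon would also leave the number unchanged remains open. On these data alone, it is also open whether the same swap would behave alike on the chain of compound 2, which lacks the methyl group, or at the remaining methoxy group.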